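The source may report more compounds than this note shows. Statements on the series, on what has been measured and on what is new or still open speak of the compounds shown alone.

Notes on the series in an ADME assay on Raji cells (Homo sapiens) for cytotoxicity, read by luminescence, with a stated time of 72 h; on this read-out lower numbers stand for an effect already at smaller amounts and higher numbers for an effect only at larger amounts of compound.

Compound 1 is `CCOC(=O)c1c(-c2cccc(OC)c2)[nH]c2cc(Cl)c(OC)cc2c1=O`. In this assay compound 1 gives > 21500 nM, which is a limit of the assay rather than a number. Compound 2 is `CCOC(=O)c1c(-c2cccc(Oc3ccccc3)c2)[nH]c2cc(Cl)c(OC)cc2c1=O` and carries the change phenyl in place of methyl on an oxygen on an aromatic ring relative to compound 1. In this assay compound 2 gives > 21500 nM, again a limit of the assay. The step that the two limits leave unreadable from compound 1 to compound 2 therefore cannot be read in size, since both ends are limits.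

Compound 3 is `CCOC(=O)c1c(-c2cccc(OC)c2)[nH]c2cc(OC)c(Cl)cc2c1=O`; the two cores of compound 1 and compound 3 are built from the same atoms joined differently, and the difference between the two cores is not broken down here. In this assay compound 3 gives > 21500 nM, which is a limit of the assay.

Compound 4, not yet measured, is `CCOC(=O)c1c(-c2cccc(Oc3ccccc3)c2)[nH]c2cc(OC)c(Cl)cc2c1=O`. It carries the change phenyl in place of methyl on an oxygen on an aromatic ring relative to compound 3. Among the compounds with values here, this is the same change as the one from compound 1 to compound 2, and the place of the change is described in the same words for both pairs.

For the step from compound 3 to compound 4 the expectation is a step that the limit leaves unreadable from compound 3 to compound 4, because the limit of > 21500 nM in this assay, at which 3 of the 3 values shown sit, leaves no readable movement anywhere in the series on which a different expectation could rest. Compound 4 is expected to come out at about 30000 nM, with a plausible range from 15000 nM to 90000 nM, and most likely to be reported again only as a limit.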

Compound 4, half-maximal effective concentration: > 21500 nM
Compound 4: no number, only a limit; the forecaster's own chance of this, stated with the estimate: 85%; the middle value is on the limit's open side.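

No step can be read between compound 3 and compound 4, and none between compound 1 and compound 2, since every value in the series is a limit and not a number: the limit of > 21500 nM in this assay, at which 4 of the 4 values shown sit.

The compounds shown leave open whether methoxy to phenoxy changes the read-out at all on either core, and how the two cores compare in this assay.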